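Chain Extension at the Sulfur Tail of a Chloromethyl Ketone Series

A few compounds are considered here, and "the series" means these few. Any claim that something is new, unique, unknown or untested is made for them only; others in the source may bear on it.

Measured so far:
Compound 1, `CCCCCCSC[C@H](NC(C)=O)C(=O)CCl`: 700 nM
Compound 2, `CCCCCCCCCCSC[C@H](NC(C)=O)C(=O)CCl`: 3400 nM
Compound 3, `CCCCCCCCCCCCSC[C@H](NC(C)=O)C(=O)CCl`: 2300 nM

All three share one core and differ only in the length of the saturated chain on the sulfur. In a functional assay on MOLT-3 cells (Homo sapiens) (a lower number here means a stronger inhibitor, a higher number a weaker inhibitor), compound 1 gives 700 nM, the lowest of the three numbers. Compound 3 stands second highest, closest to compound 2 and furthest from compound 1. The two steps out of compound 1 both raised the number: a 4.9-fold higher number from compound 1 to compound 2 (0.69 log units; beyond the scatter) and a 3.3-fold higher number from compound 1 to compound 3 (0.52 log units; beyond the scatter). Between the two longer chains, however, the step of a 1.5-fold lower number from compound 2 to compound 3 (0.17 log units; within the scatter) stays within the scatter.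

Compound 4, `CCCCCCCCCCCCCCSC[C@H](NC(C)=O)C(=O)CCl`, has not yet been measured. It differs from compound 3 by ethyl in place of hydrogen on a saturated chain carbon, ten or more bonds along the chain from a sulfur. Among the compounds with values here, the one step that matches this change, from compound 2 to compound 3, lies within the scatter, so the same change is expected to produce little or no step beyond the scatter in this assay: a 1.1-fold higher number from compound 3 to compound 4 (0.04 log units; within the scatter). The series is too short to say whether the number keeps drifting in any direction, so compound 4 is estimated at 2500 nM, with a range of 1100 nM to 5500 nM.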

Compound 4, half-maximal inhibitory concentration: 8800 nM
The estimate for compound 4 lay 3.5-fold (0.55 log units) below the measured number; measured number outside the range, above it.
By their numbers in this assay, from the lowest: compound 1; then compounds 3 and 2 (each within the scatter of the next); then compound 4.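

The ethyl in place of hydrogen is not a neutral change at this position: it gave a step within the scatter from compound 2 to compound 3, yet here in this assay it gives a 3.8-fold higher number from compound 3 to compound 4 (0.58 log units; beyond the scatter). Within the data shown here, compound 4 also stands apart from the other longer chain, with a 2.6-fold higher number from compound 2 to compound 4 (0.41 log units; beyond the scatter), and the full extension of the chain gives a 13-fold higher number from compound 1 to compound 4 (1.10 log units; beyond the scatter), so compound 4 is the weakest inhibitor of the four, and the chain of compound 1 remains the one with the lowest number. Lengthening therefore raises the number overall, but not at every step, since compound 2 and compound 3 do not separate, and no measurement offered here accounts for this uneven course.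

The compounds shown leave open how a shorter chain on the sulfur, such as butyl, or an octyl chain would read against compound 1, and whether a still longer chain would raise the number further. They also leave open what an amine or a carboxylic acid carried on the chain would do in this series.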